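This account rests on a few compounds, and the source may have more. Where it says the series, first, only, none or still open, it means among the compounds named here.

Working notes on the series.

The read-out throughout is a functional assay on the whole organism (stomach) with Rattus norvegicus as the target; a lower number here means that less compound is needed, a higher number that more compound is needed for the effect. Compound 1 `CC/N=C(/NC#N)NCCCCn1nc(-c2ccccc2)c(C)cc1=O` gives only a limit of the assay, > 100 mg/kg. Compound 3 `O=c1ccc(-c2ccccc2)nn1CCCC/N=C(\S)Nc1ccc(F)cc1` likewise gives only a limit, > 100 mg/kg. For the measured compounds named here, compound 2 `C/N=C(\NC#N)NCCCCn1nc(-c2ccccc2)ccc1=O` is the single member of the set with a number: in this assay compound 2 gives 32.4 mg/kg, so it stands alone as the one measured dose. The other two values sit at the limit of > 100 mg/kg in this assay, at which 2 of the 3 values shown sit.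

Compound 4 `CC/N=C(\S)NCCCCn1nc(-c2ccccc2)ccc1=O` is yet to be measured. It differs from compound 2 in one place: a group of 5 heavy atoms (3 carbon, 1 nitrogen, 1 sulfur; no ring) in place of a group of 6 heavy atoms (3 carbon, 3 nitrogen; no ring), on an amine nitrogen. The thiourea that enters in compound 4 is also present in compound 3, and the ethyl that enters in compound 4 is also present in compound 1; both of those compounds reached only the limit. Going by the values given here, no step between measured compounds is available, so the size of the step cannot be read from the data, only guessed from these two neighbours.

The expectation is therefore that compound 4 needs more compound than compound 2, with the step of a 2.5-fold higher number from compound 2 to compound 4 (0.39 log units; beyond the scatter) estimated as going beyond the usual scatter toward higher dose. The estimate for compound 4 in this assay is 80 mg/kg, in a range from 30 mg/kg to 250 mg/kg, with a real chance that only a limit is reported.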

Compound 4, dose for half-maximal effect: 37.2 mg/kg
The estimate for compound 4 lay 2.2-fold (0.33 log units) above the measured number, within the range that was stated.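

In this assay, the thiourea group that enters on the amine nitrogen gives a 1.1-fold higher number from compound 2 to compound 4 (0.06 log units; within the scatter), so in this pair a measured dose does not depend on the group with the nitrile. For the compounds shown here, compound 4 carries both the thiourea and the ethyl and still gives a number, so neither of the two brings the assay limit on its own, which the earlier compounds could not show. Compound 1 and compound 3 remain limits and not numbers, so no step to either of them can be read: the limit of > 100 mg/kg in this assay, at which 2 of the 4 values shown sit.

As far as these compounds go, what separates these two compounds from the measured pair stays open, whether the extra methyl of compound 1 or the fluorophenyl of compound 3, and each of these two groups is seen only once. Also open, from the compounds shown here alone, is how the dose would respond to a urea or a carboxylic acid in place of the group on the amine nitrogen, or to a shorter chain linking that nitrogen to the core.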